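Side-chain variation on the shared core, ileum potency

The source may hold more compounds than are shown below. What is called first, only, known or untested is meant among the compounds shown, and "the series" means these compounds.

Among the compounds with values here, compound 3 `C#CCOCCn1c(N2CCN(C)CC2)nc2ccccc21` gives 12 nM in a functional assay on ileum for inhibition of histamine H1 receptor (Cavia porcellus) (a higher number here means a weaker inhibitor, a lower number a stronger inhibitor), the lowest of the three numbers so far. Compound 2 `CCSCCn1c(N2CCN(C)CC2)nc2ccccc21` gives 19 nM and sits nearest, with a 1.6-fold lower number from compound 2 to compound 3 (0.20 log units; within the scatter). Compound 1 `CCNCCn1c(N2CCN(C)CC2)nc2ccccc21` gives 290 nM and lies furthest off, with a 24-fold lower number from compound 1 to compound 3 (1.38 log units; beyond the scatter) and a 15-fold lower number from compound 1 to compound 2 (1.18 log units; beyond the scatter). Compound 4 `CCCCCCCCCCn1c(N2CCN(C)CC2)nc2ccccc21` carries octyl in place of propargyloxy on a saturated chain carbon, two bonds along the chain from an aromatic nitrogen. Within the data shown here, no measured step bears directly on this: the two large steps both replace ethylamino, and the step from ethylsulfanyl to propargyloxy stays within the scatter. The move to octyl is therefore unanchored and is expected to cost some potency, a step of a 3.3-fold higher number from compound 3 to compound 4 (0.52 log units; beyond the scatter). For compound 4 the estimate in this assay is 40 nM, ranging from 8 nM to 200 nM.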

Compound 4, half-maximal inhibitory concentration: 4200 nM
The estimate for compound 4 lay 110-fold (2.02 log units) below the measured number; the whole stated range lies below it.
By their numbers in this assay, from the lowest: compounds 3 and 2 (each within the scatter of the next); then compound 1; then compound 4.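

Replacing ethylamino at this position does not always lower the number: in this assay octyl reverses the earlier direction, with a 14-fold higher number from compound 1 to compound 4 (1.16 log units; beyond the scatter) as the result. Within the data shown here, the loss is greater against the two side chains that lead the series, with a 350-fold higher number from compound 3 to compound 4 (2.54 log units; beyond the scatter) and a 220-fold higher number from compound 2 to compound 4 (2.34 log units; beyond the scatter) standing as the largest steps so far. Still open, as far as these compounds go, is whether the loss follows the chain's length or the absence of a heteroatom, which a butyl chain or a longer ether chain would help separate. No evidence is available on the cause of this loss.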